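Adding a Methoxy Group to an Inactive Chromone Amide

This account rests on a few compounds, and the source may have more. Where it says the series, first, only, none or still open, it means among the compounds named here.

Compound 1 `COc1ccc2c(=O)c(/C=C/C(=O)Nc3ccccc3)coc2c1`: in a functional assay on L02 cells (Homo sapiens) for inhibition, read by MTT assay, with a stated time of 48 h (on this read-out lower numbers stand for stronger inhibition and higher numbers for weaker inhibition), compound 1 gives > 200000 nM, a limit of the assay rather than a number.
Compound 2 `COc1ccc2c(=O)c(/C=C/C(=O)Nc3ccc(Cl)cc3)coc2c1`: in this assay compound 2 gives > 200000 nM, again only a limit.
Compound 3 `Cc1ccc(CNC(=O)/C=C/c2coc3cc(O)ccc3c2=O)cc1`: in this assay compound 3 gives > 200000 nM, also a limit.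

Compound 1 therefore stands nowhere definite on the scale: all that is known is that it did not reach the threshold of the assay. The same holds across the whole set, since (the limit of > 200000 nM in this assay, at which 3 of the 3 values shown sit). Among the compounds with values here, the only measured step between neighbours, a step that the two limits leave unreadable from compound 1 to compound 2, is chloro in place of hydrogen on an aromatic carbon. Both ends of that step are limits, and its size cannot be read.

Compound 4 `COc1ccc(NC(=O)/C=C/c2coc3cc(OC)ccc3c2=O)cc1` differs from compound 1 by methoxy in place of hydrogen on an aromatic carbon. The nearest comparison, the step to compound 2, also adds a small group on an aromatic carbon and left the value at the limit, so no readable change of any direction can be drawn from it. Compound 4 is expected to stay at the limit as well, with the step that the limit leaves unreadable from compound 1 to compound 4 expected to be unreadable. The estimate for compound 4 is 300000 nM, expected between 100000 nM and 1000000 nM.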

Compound 4, half-maximal inhibitory concentration: > 200000 nM
Compound 4 was reported as a limit (the forecaster's own chance of this, stated with the estimate: 85%); the middle value is on the limit's open side.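

Compound 4 gives only a limit, as do compound 1 and compound 2, so the steps to compound 4 from compound 1 and from compound 2 cannot be read. The compounds shown leave open whether any change to the shared core would give a measurable value in this assay.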